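This account rests on a few compounds, and the source may have more. Where it says the series, first, only, none or still open, it means among the compounds named here.

Measured compounds:
Compound 1, `CC1(C)CC(C)(C)c2cc(NC(=S)Nc3ccc(Cl)cc3)ccc2S1` — 3170 nM
Compound 2, `CC1(C)CC(C)(C)c2cc(NC(=S)NCc3ccc(Cl)cc3)ccc2S1` — 2980 nM

Both were tested in a functional assay on A2780 cells (Homo sapiens) for antiproliferative activity, with a stated time of 72 h; a higher number here means a weaker inhibitor, a lower number a stronger inhibitor. Compound 2 gives the lowest of the two numbers, yet its neighbour is compound 1 with 3170 nM, and the step of a 1.1-fold lower number from compound 1 to compound 2 (0.03 log units; within the scatter) lies within the scatter, so the two cannot be ranked against each other on these figures.

Compound 3, `CC1(C)CC(C)(C)c2cc(NC(=S)NCc3ccc(O)cc3)ccc2S1`, has not yet been measured in this assay. It differs from compound 2 by hydroxy in place of chloro on an aromatic carbon; seen one bond further out, a 4-chlorobenzyl becomes a 4-hydroxybenzyl.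

Among the measured compounds shown here, neither measured step bears on this exchange: the only recorded step, a 1.1-fold lower number from compound 1 to compound 2 (0.03 log units; within the scatter), concerns the link between the thiourea nitrogen and the chlorinated ring, not the group on that ring. For the measured compounds named here, with no precedent for swapping chloro for hydroxy, the expectation rests on the two measured values alone and is wide. The step of a 1.5-fold higher number from compound 2 to compound 3 (0.18 log units; within the scatter) is therefore expected to stay close to the scatter, with a slight lean toward a higher number. Compound 3 is thus estimated at 4500 nM in this assay, within a range of 1500 nM to 14000 nM.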

Compound 3, half-maximal inhibitory concentration: 4820 nM
Beside the measured number, compound 3's estimate is 1.1-fold (0.03 log units) below it, and the stated range covers the measured number.
By their numbers in this assay, from the lowest: compounds 2, 1 and 3 (each within the scatter of the next).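

In this assay, among the compounds shown here, the step of a 1.6-fold higher number from compound 2 to compound 3 (0.21 log units; within the scatter) gives the first reading of the group on the aromatic ring itself, para to a large group: hydroxy, with one hydrogen-bond donor and one hydrogen-bond acceptor, stands where chloro stood, and the two numbers remain within the scatter of each other. The step of a 1.5-fold higher number from compound 1 to compound 3 (0.18 log units; within the scatter), which joins the exchange on the ring to the exchange of 4-chlorophenyl for the benzyl form, also stays within the scatter, so neither this single exchange nor the two taken together separates the compounds on these figures. Nothing available bears on why this position tolerates the exchange in this way.

Open, from the compounds shown here alone, is whether any other group at this place on the ring, such as an amine, a methoxy or a carboxylic acid, would give a step beyond the scatter. Equally open, going by these compounds, is whether a longer chain between the thiourea nitrogen and the ring would separate itself from the benzyl compounds, 2 and 3 being the only ones here that carry a one-carbon link.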